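Swapping the amide-bound ring system and its effect on stability

A few compounds are considered here, and "the series" means these few. Any claim that something is new, unique, unknown or untested is made for them only; others in the source may bear on it.

Measured compounds:
Compound 1, `O=C(NCc1ccc(S(=O)(=O)c2cccc(C(F)(F)F)c2)cc1)c1cc2cnccc2[nH]1`, in an ADME assay on microsomes from liver (Homo sapiens) for metabolic stability, read by LC-MS, with a stated time of 30 min, tested at 1 uM (on this read-out higher numbers stand for a more stable compound and lower numbers for a less stable compound), compound 1 gives 81%.
Compound 2, `O=C(NCc1ccc(S(=O)(=O)c2cccc(C(F)(F)F)c2)cc1)c1cnc2nccn2c1`, in this assay compound 2 gives 41%.
Compound 3, `O=C(NCc1ccc(S(=O)(=O)c2ccccc2)cc1)c1cc2cnccc2[nH]1`, in this assay compound 3 gives 75%.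

All three share a benzylamide carrying a sulfonyl-linked phenyl ring; they differ in two places. Compound 1 and compound 3 differ only on that phenyl ring: hydrogen in place of trifluoromethyl on an aromatic carbon. The step there is a number 6 percentage points lower from compound 1 to compound 3 (within the scatter), so the two numbers cannot be told apart.

Compound 1 and compound 2 differ in the ring system attached to the carbonyl carbon: a group of 9 heavy atoms (6 carbon, 3 nitrogen; one five-membered aromatic ring with 2 hetero atoms, one six-membered aromatic ring with 2 hetero atoms) in place of a group of 9 heavy atoms (7 carbon, 2 nitrogen; one five-membered aromatic ring with 1 hetero atom, one six-membered aromatic ring with 1 hetero atom), on a carbonyl carbon. Here the step is a number 40 percentage points lower from compound 1 to compound 2 (beyond the scatter), a clear loss of stability.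

Compound 4, `O=C(NCc1ccc(S(=O)(=O)c2ccccc2)cc1)c1cnc2nccn2c1`, is not yet measured. It stands to compound 3 exactly as compound 2 stands to compound 1: a group of 9 heavy atoms (6 carbon, 3 nitrogen; one five-membered aromatic ring with 2 hetero atoms, one six-membered aromatic ring with 2 hetero atoms) in place of a group of 9 heavy atoms (7 carbon, 2 nitrogen; one five-membered aromatic ring with 1 hetero atom, one six-membered aromatic ring with 1 hetero atom), on a carbonyl carbon. The place of the change is the same in both pairs, so this is the same change made on a core that differs from compound 1 only by hydrogen in place of trifluoromethyl on an aromatic carbon, a difference that left the read-out unchanged within the scatter.

Going by the values given here, because a number 40 percentage points lower from compound 1 to compound 2 (beyond the scatter) is the only measured instance of this change, the expectation for compound 4 rests on it alone: the step from compound 3 is estimated as a number 39 percentage points lower from compound 3 to compound 4 (beyond the scatter). In this assay compound 4 is therefore expected to give about 36%, estimated to lie between 20% and 52%.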

Compound 4, percent of the compound remaining: 60%
Compound 4: the middle estimate sits 24 percentage points below what was measured; measured number above the stated range.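

The change on the carbonyl carbon lowers the number again in this assay, with a number 15 percentage points lower from compound 3 to compound 4 (beyond the scatter), so its direction is the same on both cores, but its size is not carried over from one core to the other: the same change on two cores in this assay, a number 40 percentage points lower (beyond the scatter) from compound 1 to compound 2 and a number 15 percentage points lower (beyond the scatter) from compound 3 to compound 4, 25 percentage points apart, beyond the scatter of two such steps. Seen from the other side, the swap of trifluoromethyl for hydrogen also depends on which group sits on the carbonyl carbon, and with the group that enters in compound 2 and compound 4 it gives a number 19 percentage points higher from compound 2 to compound 4 (beyond the scatter), so the two changes do not act independently of each other here: the same change on two cores in this assay, a number 6 percentage points lower (within the scatter) from compound 1 to compound 3 and a number 19 percentage points higher (beyond the scatter) from compound 2 to compound 4, 25 percentage points apart, beyond the scatter of two such steps. These four compounds form a single set of paired changes, so they show that a step measured on one core can be a poor guide to its size on the other, but they do not show why the steps differ or how the change would behave on any further core.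

As far as these compounds go, it remains open whether a chlorine or a methoxy group in place of the trifluoromethyl would shrink the loss as hydrogen does or leave it as large as in compound 2. From the compounds shown here alone, it also remains open whether a simple phenyl ring on the carbonyl carbon would show the same dependence on the far ring.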